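Swapping a cyclohexyl thiourea for an aryl sulfonamide

The compounds below may be only part of what the source reports. "The series", "measured", "known", "first", "only" and "open" are said of these compounds alone.

Measured compounds:
- Compound 1, `Cn1nc(COc2cc(F)cc(F)c2)c2c1CCN(C(=O)Nc1ccc(Cl)cc1)C2`: in an assay on cells for inhibition of Pendrin (Mus musculus), read by fluorescence, with a stated time of 10 min (a higher number here means a weaker inhibitor, a lower number a stronger inhibitor), compound 1 gives 3100 nM.
- Compound 2, `CC(C)NC(=O)N1CCc2c(c(COc3cc(F)cc(F)c3)nn2C)C1`: here compound 2 sits at a limit of the assay, > 10000 nM.
- Compound 3, `Cn1nc(COc2cc(F)cc(F)c2)c2c1CCN(C(=S)NC1CCCCC1)C2`: compound 3 likewise sits at a limit, > 10000 nM.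

Compound 3 therefore stands at the weak end of what was measured, together with compound 2, both at the limit of > 10000 nM in this assay, at which 2 of the 3 values shown sit. The unmeasured compound 4, `Cn1nc(COc2cc(F)cc(F)c2)c2c1CCN(S(=O)(=O)c1ccc(Cl)cc1)C2`, arises from compound 3 by one change: a group of 10 heavy atoms (6 carbon, 2 oxygen, 1 sulfur, 1 chlorine; one six-membered aromatic ring of carbon only) in place of a group of 9 heavy atoms (7 carbon, 1 nitrogen, 1 sulfur; one six-membered non-aromatic ring of carbon only), on an amine nitrogen in a ring. Within the data shown here, only one measured step runs in a related direction, an at least 3.2-fold higher number from compound 1 to compound 3 (0.50 log units; beyond the scatter), where replacing a 4-chlorophenyl group by the cyclohexyl thiourea cost at least a modest amount of potency; an at least 3.2-fold higher number from compound 1 to compound 2 (0.50 log units; beyond the scatter) tells a similar story for an isopropyl group. The step that the two limits leave unreadable from compound 2 to compound 3 cannot be read. Compound 4 brings a 4-chlorophenyl ring back, so a number somewhat below the limit, closer to compound 1, is expected, meaning an at least 2.0-fold lower number from compound 3 to compound 4 (0.30 log units; that floor lies within the scatter). Compound 4 is estimated at 5000 nM, within 1500 nM to 15000 nM.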

Compound 4, half-maximal inhibitory concentration: > 10000 nM
Compound 4: no number, only a limit; the forecaster's own chance of this, stated with the estimate: 40%; at least 2.0-fold (0.30 log units) between middle value and limit.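

In this assay, putting (4-chlorophenyl)sulfonyl in place of (4-chlorophenyl)carbamoyl on the amine nitrogen gives an at least 3.2-fold higher number from compound 1 to compound 4 (0.50 log units; beyond the scatter). The 4-chlorophenyl ring alone therefore does not restore the activity seen with compound 1, and the link that joins this ring to the core matters as well. Compound 1 is now the only compound here with a measured number rather than a limit: the limit of > 10000 nM in this assay, at which 3 of the 4 values shown sit.

The steps from compound 2 and from compound 3 to compound 4 cannot be read, as both ends of each are limits. Still open, on these data alone, is whether a link such as 4-chlorobenzoyl could retain activity, and whether a methoxy group or a nitrile in place of the chlorine on the carbamoyl-linked ring would strengthen or weaken it.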